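Methyl for Chloro on a Dopamine Receptor Ligand

A few compounds are considered here, and "the series" means these few. Any claim that something is new, unique, unknown or untested is made for them only; others in the source may bear on it.

Compound 1, `O/N=C(/CCN1CCN(c2ccccn2)CC1)c1ccccc1Cl`: in a functional assay on HEK293 cells with D(4) dopamine receptor (Homo sapiens) as the target, read by FLIPR (a higher number here means a larger maximal response, a lower number a smaller maximal response), compound 1 gives 64%.
Compound 2, `Cc1ccccc1/C(CCN1CCN(c2ccccn2)CC1)=N\O`: compound 2 gives 72%.
Compound 3, `O/N=C(\CCN1CCN(c2ccccn2)CC1)c1cccc(Cl)c1`: compound 3 gives 73%.

Compound 1 and compound 2 share one core and differ in a single place: methyl in place of chloro on an aromatic carbon. The measured step for that exchange is a number 8 percentage points higher from compound 1 to compound 2 (within the scatter), so the two compounds cannot be told apart with confidence in this assay. Compound 3 is built from the same atoms as compound 1, joined differently; the difference between the two cores is not broken down here. The three measured values all lie within the usual scatter of one another, so none of them can be called the strongest or weakest.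

Compound 4, `Cc1cccc(/C(CCN2CCN(c3ccccn3)CC2)=N/O)c1`, has not yet been measured. It differs from compound 3 in one place: methyl in place of chloro on an aromatic carbon. Among the compounds with values here, this is the same kind of change as the one from compound 1 to compound 2, but the surroundings differ: in compound 1 the place is ortho to a large group, in compound 3 it is meta to a large group. A small step is expected, estimated at a number 5 percentage points higher from compound 3 to compound 4 (within the scatter), because a number 8 percentage points higher from compound 1 to compound 2 (within the scatter) was itself small. Compound 4 is therefore expected to give about 78% in this assay, most likely between 66% and 90%.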

Compound 4, largest response reached (reported as efficacy), in percent of the reference or control that the assay uses: 74%
Estimate against measurement, compound 4: 4 percentage points above, and the stated range covers the measured number.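

On the core of compound 3, the exchange of 3-chlorophenyl for 3-methylphenyl in this assay gives a measured step of a number 1 percentage points higher from compound 3 to compound 4 (within the scatter), so these two compounds cannot be told apart with confidence. Set beside the earlier exchange on the core of compound 1, the new step gives no sign that the effect of this change depends on the core: the same change on two cores in this assay, a number 8 percentage points higher (within the scatter) from compound 1 to compound 2 and a number 1 percentage points higher (within the scatter) from compound 3 to compound 4, 7 percentage points apart, within the scatter of two such steps With both steps inside the scatter, this says only that methyl in place of chloro left no readable mark on the maximal response on these two cores, and it does not show that the two groups are interchangeable in general, on a further core, or in any other kind of measurement.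

What a methoxy group, a trifluoromethyl group or a plain hydrogen would give at the same place on the aromatic ring remains open, since the compounds shown carry only chloro and methyl there. Also open, as far as these compounds go, is how the response would move with a longer chain in the shared core, which would test a different part of these molecules.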